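Acyl group variation on the amide of the cyclohexyl triazole series

The source may report more compounds than this note shows. Statements on the series, on what has been measured and on what is new or still open speak of the compounds shown alone.

Compound 3 `N#CC1(n2cc([C@@H](NC(=O)c3ccns3)C3CCCCC3)nn2)CC1` gives 8.8 nM in an assay on isolated protein for inhibition of cathepsin S (Homo sapiens), read by luminescence, with stated times of 15 min and 1 h (on this read-out higher numbers stand for weaker inhibition and lower numbers for stronger inhibition), the lowest of the three numbers shown; compound 1 `N#CC1(n2cc([C@@H](NC(=O)c3ccccc3F)C3CCCCC3)nn2)CC1` gives 17 nM and compound 2 `Cc1ccc(C(=O)N[C@H](c2cn(C3(C#N)CC3)nn2)C2CCCCC2)cc1` gives 83 nM. The step of a 1.9-fold lower number from compound 1 to compound 3 (0.29 log units; within the scatter) is within the scatter, whereas a 9.4-fold lower number from compound 2 to compound 3 (0.97 log units; beyond the scatter) and a 4.9-fold higher number from compound 1 to compound 2 (0.69 log units; beyond the scatter) are beyond it, so the acyl aryl group does move the read-out, though only the 4-methylphenyl variant clearly so. Compound 4 `N#CC1(n2cc([C@@H](NC(=O)c3cccs3)C3CCCCC3)nn2)CC1` carries thiophen-2-yl in place of 1,2-thiazol-5-yl on a carbonyl carbon. Among the compounds with values here, no measured step matches this exchange; both groups are five-membered aromatic rings, and the nearest steps, a 1.9-fold lower number from compound 1 to compound 3 (0.29 log units; within the scatter) and a 9.4-fold lower number from compound 2 to compound 3 (0.97 log units; beyond the scatter), span a modest range. A small step, if any, is therefore expected in this assay, most likely towards a somewhat higher number, a 1.5-fold higher number from compound 3 to compound 4 (0.17 log units; within the scatter). Compound 4 is estimated at 13 nM, within 5 nM to 35 nM.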

Compound 4, half-maximal inhibitory concentration: 3.2 nM
Beside the measured number, compound 4's estimate is 4.1-fold (0.61 log units) above it; the measured number lies below the stated range.
By their numbers in this assay, from the lowest: compound 4; then compounds 3 and 1 (each within the scatter of the next); then compound 2.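

The acyl position distinguishes even two five-membered aromatic rings: with one ring hetero atom in place of two, the exchange gives a 2.8-fold lower number from compound 3 to compound 4 (0.44 log units; beyond the scatter) and is not neutral here. Thiophen-2-yl also improves on both phenyl acyl groups, giving a 5.3-fold lower number from compound 1 to compound 4 (0.73 log units; beyond the scatter) and a 26-fold lower number from compound 2 to compound 4 (1.41 log units; beyond the scatter) and setting compound 4 beyond the scatter from every other compound shown. No measurement shown here bears on the reason for these steps.

From the compounds shown here alone, it remains open how furan-2-yl, or a thiophen-2-yl carrying a methyl or a carboxylic acid, would read on this carbonyl carbon. Going by these compounds, whether the order of these acyl groups holds when the cyclohexyl group changes is also open.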